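This account rests on a few compounds, and the source may have more. Where it says the series, first, only, none or still open, it means among the compounds named here.

Measured so far:
compound 1, `C/C(NNC(=S)N1CCc2cc(C(=O)O)ccc21)=C1/C(=O)N(c2ccc3c(c2)CCC3)c2ccccc21`, 14.3%
compound 2, `C/C(NNC(=S)N1CCc2cc(C(=O)O)ccc21)=C1/C(=O)N(c2ccc3c(c2)CCC3)c2ccc(F)cc21`, 3.2%
compound 3, `C/C(NNC(=S)N1CCCc2cc(C(=O)O)ccc21)=C1/C(=O)N(c2ccc(C)cc2)c2ccccc21`, 47.3%

Among the measured compounds shown here, in an assay on BaF3 cells for inhibition of thrombopoietin receptor (Homo sapiens), tested at 150 nM (a higher number here means a stronger effect of the compound at the concentration tested, a lower number a weaker effect), compound 1 sits second of the three numbers: compound 2 is the nearer one, with the one characterised step a number 11.1 percentage points lower from compound 1 to compound 2 (beyond the scatter), and compound 3 is the furthest, higher by a margin beyond the scatter. Compound 3 differs from compound 1 in two places at once, the ring size on the thiosemicarbazide side and the group on the amide-type nitrogen, so its higher value cannot be assigned to either change alone.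

Compound 4, `C/C(NNC(=S)N1CCc2cc(C(=O)O)ccc21)=C1/C(=O)N(c2ccc(C)cc2)c2ccccc21`, is compound 1 with one change: 4-methylphenyl in place of 2,3-dihydro-1H-inden-5-yl on an amide-type nitrogen in a ring. For the measured compounds named here, no measured step covers this change. The fluoro step from compound 1 to compound 2 concerns a different position and does not inform it. Going by the values given here, the only pointer is compound 3, which carries the same 4-methylphenyl and gives 47.3%, but with the other change confounded.

The expected step is therefore upward but uncertain: a number 15.7 percentage points higher from compound 1 to compound 4 (beyond the scatter). In this assay compound 4 is estimated at 30%, with a range from 10% to 55%.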

Compound 4, a percentage reported as inhibition, at one concentration (the size of the read-out at that concentration, not a potency): 47.8%
For compound 4 the middle estimate is 17.8 percentage points below the measured one, and the stated range covers the measured number.
By their numbers in this assay, from the lowest: compound 2; then compound 1; then compounds 3 and 4 (each within the scatter of the next).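

Working notes on the group on the amide-type nitrogen in a ring: in this assay, 4-methylphenyl in place of 2,3-dihydro-1H-inden-5-yl gives a number 33.5 percentage points higher from compound 1 to compound 4 (beyond the scatter), the first reading of this change on its own, and it shows that the read-out responds strongly to the group at this place. Compound 3 at 47.3% and compound 4 at 47.8% lie within the scatter of each other, and as they differ only in the ring size on the thiosemicarbazide side, that ring size shows no effect on the read-out in this pair, while the gap between compound 1 and compound 3 no longer has to be split between two changes with the same weight. No measured information bears on why the 4-methylphenyl group gives the higher number.

As far as these compounds go, it remains open whether the methyl group is needed at all, which plain phenyl would test, and whether 4-methoxyphenyl, 4-chlorophenyl or cyclohexyl on the same nitrogen would hold the value of compound 4. Also open, from the compounds shown here alone, is whether fluoro in place of hydrogen on an aromatic carbon lowers the number in the 4-methylphenyl compounds as it does from compound 1 to compound 2.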